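The compounds below may be only part of what the source reports. "The series", "measured", "known", "first", "only" and "open" are said of these compounds alone.

Three compounds share one core and differ only in the group carried on a saturated chain carbon bound to an aromatic carbon and a saturated chain carbon. Compound 1 `CC(C)C(Cc1ncc[nH]1)c1ccc(-c2ccc3cccc(F)c3c2)[nH]c1=O` gives 0.106 h in an ADME assay on microsomes from liver (Homo sapiens) for metabolic stability; a higher number here means that the compound lasts longer, a lower number that the compound disappears faster. Compound 2 `CC(C)C(c1ccc(-c2ccc3cccc(F)c3c2)[nH]c1=O)N1CCN/C1=N\C#N` gives 0.632 h in this assay, and compound 3 `CC(C)C(c1ncco1)c1ccc(-c2ccc3cccc(F)c3c2)[nH]c1=O` gives 0.178 h. Among these three numbers compound 3 stands second highest: its nearest neighbour is compound 1, since the step of a 1.7-fold higher number from compound 1 to compound 3 (0.23 log units; within the scatter) is within the scatter, while the step of a 3.6-fold lower number from compound 2 to compound 3 (0.55 log units; beyond the scatter) sets compound 2 further away.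

Compound 4 `CC(C)C(c1cnc(N)s1)c1ccc(-c2ccc3cccc(F)c3c2)[nH]c1=O` is not yet measured. The change from compound 3 is 2-amino-1,3-thiazol-5-yl in place of 1,3-oxazol-2-yl on a saturated chain carbon bound to an aromatic carbon and a saturated chain carbon. The two measured steps that bear on it are the ones that also swap the group on this chain carbon: a 1.7-fold higher number from compound 1 to compound 3 (0.23 log units; within the scatter) and a 3.6-fold lower number from compound 2 to compound 3 (0.55 log units; beyond the scatter). Swapping one five-membered aromatic ring with 2 hetero atoms for another, as in the step from compound 1 to compound 3, gave only a difference within the scatter, whereas the larger non-aromatic group of compound 2 stood apart. Since compound 4 keeps a five-membered aromatic ring with 2 hetero atoms, the expected step of a 1.1-fold higher number from compound 3 to compound 4 (0.05 log units; within the scatter) is small, within the scatter. Compound 4 is therefore estimated to give 0.2 h, in a range from 0.08 h to 0.5 h.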

Compound 4, half-life: 0.178 h
Compound 4: middle estimate off by 1.1-fold (0.05 log units), on the high side; the range from low to high includes it.
By their numbers in this assay, from the lowest: compounds 1, 3 and 4 (each within the scatter of the next); then compound 2.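

In this assay, the result (no change at the digits printed from compound 3 to compound 4 (within the scatter)) shows that this saturated chain carbon can carry 2-amino-1,3-thiazol-5-yl, which brings sulfur and a hydrogen-bond donor, in place of 1,3-oxazol-2-yl without a change beyond the scatter. Among the compounds shown here, the comparison with the first compound (a 1.7-fold higher number from compound 1 to compound 4 (0.23 log units; within the scatter)) puts compounds 1, 3 and 4 together, so three different groups that each hold a five-membered aromatic ring with 2 hetero atoms now sit within the scatter, while the comparison with the non-aromatic group (a 3.6-fold lower number from compound 2 to compound 4 (0.55 log units; beyond the scatter)) leaves compound 2 apart as the one compound that goes against this grouping. No measurement at hand explains why these groups match or why compound 2 stands apart.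

As far as these compounds go, whether the higher number of compound 2 goes with its non-aromatic ring or with its nitrile stays open, as that ring and the nitrile appear together in this one compound. From the compounds shown here alone, it is also open how this position would respond to a group of another kind, such as a simple amine or a carboxylic acid, on the same chain carbon.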